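One Bromine on the Fused Ring of Compound 2

A few compounds are considered here, and "the series" means these few. Any claim that something is new, unique, unknown or untested is made for them only; others in the source may bear on it.

Compound 2, `O=c1cc(-c2ccccc2)oc2ccc(N3COc4ccccc4C3)cc12`, was examined in a functional assay on MCF7 cells (Homo sapiens) for inhibition, read by MTT assay, with a stated time of 48 h, tested at 15 ug/mL (on this read-out lower numbers stand for less inhibition of growth and higher numbers for more inhibition of growth at the one concentration tested), where compound 2 gives 34%. Among the three compounds measured, compound 2 stands second highest. Compound 1, `O=c1cc(-c2ccccc2)oc2ccc(N3COc4c(Br)cc(Br)cc4C3)cc12`, which carries two bromines on its fused ring, gives 13.6% in this assay, a number lying below compound 2 by more than the usual scatter. Compound 3, `O=c1cc(-c2ccccc2)oc2ccc(N3COc4c(Cl)cc(Cl)cc4C3)cc12`, which carries two chlorines instead, gives 61.3% in this assay, lying above compound 2 by more than the scatter. Within the data shown here, no pair of these measured compounds differs in only one place, so no single step can be read from them.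

Compound 4, `O=c1cc(-c2ccccc2)oc2ccc(N3COc4c(Br)cccc4C3)cc12`, differs from compound 2 in one place: bromo in place of hydrogen on an aromatic carbon. The step from compound 2 to compound 4 is expected to be a modest decrease, perhaps no larger than the scatter, because compound 1 gives 13.6% with two bromines where compound 2 has none: a number 9 percentage points lower from compound 2 to compound 4 (within the scatter). Compound 4 is therefore expected to give about 25%, within a range from 10% to 45%.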

Compound 4, percent growth inhibition at one concentration: 37.8%
The estimate for compound 4 lay 12.8 percentage points below the measured number; the range from low to high includes it.
By their numbers in this assay, from the lowest: compound 1; then compounds 2 and 4 (each within the scatter of the next); then compound 3.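

In this assay, bromo in place of hydrogen on this aromatic carbon, ortho to a fused ring, gives a number 3.8 percentage points higher from compound 2 to compound 4 (within the scatter), so a single bromo at this position leaves the number within the scatter of the unsubstituted compound. Removing the other bromo, replacing it with hydrogen on an aromatic carbon, gives a number 24.2 percentage points higher from compound 1 to compound 4 (beyond the scatter), which ties the low number of compound 1 to the presence of that second bromo alongside the first, and not to the bromo at this position alone. Nothing among the data given explains either step.

Going by these compounds, it remains open whether the second bromo would lower the number on its own, with hydrogen at this position. On these data alone, it is also open whether a methoxy group or an amine on this aromatic carbon would move the number beyond the scatter.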